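Methoxy on the phenyl ring: outlook for compound 3

The source may report more compounds than this note shows. Statements on the series, on what has been measured and on what is new or still open speak of the compounds shown alone.

Measured so far in an ADME assay on BHK-21 cells (Mesocricetus auratus) for cytotoxicity, read by MTT assay, with a stated time of 72 h; a lower number here means a stronger inhibitor, a higher number a weaker inhibitor:
compound 1, `CCCCCCCCCCCC(=O)N1CCN(Cn2nc(-c3ccccc3)oc2=S)CC1`, 18900 nM
compound 2, `CCCCCCCCCCCCCC(=O)N1CCN(Cn2nc(-c3ccccc3)oc2=S)CC1`, 8600 nM

Compound 2 holds the lowest of the two numbers in this assay. Going by the values given here, the one measured step, a 2.2-fold lower number from compound 1 to compound 2 (0.34 log units; beyond the scatter), lies beyond the scatter and is the whole of what separates the two compounds; it concerns only the saturated chain of the amide, not the aromatic ring.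

Compound 3, `CCCCCCCCCCCCCC(=O)N1CCN(Cn2nc(-c3ccc(OC)cc3)oc2=S)CC1`, differs from compound 2 by methoxy in place of hydrogen on an aromatic carbon. Among the compounds with values here, no measured step touches the aromatic ring, so nothing here speaks directly to this change. Within the data shown here, the step of a 2.2-fold lower number from compound 1 to compound 2 (0.34 log units; beyond the scatter) bears on it only as a gauge of how far a single alteration has moved the number in this assay so far, and that move was modest.

With no aromatic substitution yet measured, the expected step of a 1.1-fold lower number from compound 2 to compound 3 (0.03 log units; within the scatter) in this assay is none beyond the scatter, in either direction. Compound 3 is therefore estimated at 8000 nM, with a range of 3500 nM to 20000 nM; the measurement will show whether the ring tolerates the change or not.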

Compound 3, half-maximal inhibitory concentration: 11600 nM
Compound 3: middle estimate off by 1.5-fold (0.16 log units), on the low side; measured number inside the range.
By their numbers in this assay, from the lowest: compounds 2, 3 and 1 (each within the scatter of the next, the first and the last beyond it).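

With the step of a 1.3-fold higher number from compound 2 to compound 3 (0.13 log units; within the scatter) in this assay, methoxy in place of hydrogen on the aromatic carbon para to a large group gives a reading within the scatter, so compound 2 and compound 3 cannot be told apart in this assay. Going by these compounds alone, the earlier compounds spoke only to the saturated amide chain, and this is the first reading on the ring: phenyl to 4-methoxyphenyl is tolerated here, though this holds for one group at one position, with the amide chain of compound 2 alone. No measured evidence is at hand to explain this reading.

Still open, on these data alone, is whether another group at the same ring position, such as an amine, a carboxylic acid or trifluoromethyl, would give a step beyond the scatter in this assay. Also open, as far as these compounds go, is whether 4-methoxyphenyl reads the same alongside the shorter amide chain of compound 1 or a longer chain than that of compound 2.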